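Methoxy for methylamino: expected effect on compound 4

The compounds below may be only part of what the source reports. "The series", "measured", "known", "first", "only" and "open" are said of these compounds alone.

Compound 1 `Cc1ncnc2c1c(I)cn2[C@@H]1O[C@H](CO)[C@@H](O)[C@H]1O` gives 3460 nM in a functional assay on HepG2 cells (Homo sapiens) for antiproliferative activity, read by XTT assay, with a stated time of 72 h; on this read-out lower numbers stand for stronger inhibition and higher numbers for weaker inhibition. Compound 2 `COc1ncnc2c1c(-c1ccccc1)cn2[C@@H]1O[C@H](CO)[C@@H](O)[C@H]1O` gives only a limit in this assay, > 20000 nM. Compound 3 `CNc1ncnc2c1c(I)cn2[C@@H]1O[C@H](CO)[C@@H](O)[C@H]1O` likewise gives only a limit, > 20000 nM. Compound 3 thus stands at the limit of > 20000 nM in this assay, at which 2 of the 3 values shown sit, with no number of its own. Among the measured compounds shown here, the single measured step, an at least 5.7-fold higher number from compound 1 to compound 3 (0.76 log units; beyond the scatter), carries the value past that limit. Compound 4 `COc1ncnc2c1c(I)cn2[C@@H]1O[C@H](CO)[C@@H](O)[C@H]1O` differs from compound 3 as methoxy in place of methylamino on an aromatic carbon. For the measured compounds named here, no measured step covers this exchange; compound 2, which also carries a methoxy, sits at the same limit. The step of a number no higher from compound 3 to compound 4 (the limit leaves the size open) is expected to be none beyond the scatter. Compound 4 is estimated at 20000 nM, within 8000 nM to 50000 nM, most likely again reported as a limit.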

Compound 4, half-maximal inhibitory concentration: > 20000 nM
Compound 4 gave a limit, no number (the forecaster's own chance of this, stated with the estimate: 65%); the middle value lies on the limit itself.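

In this assay, methoxy on this aromatic carbon, with the iodo kept, gives an at least 5.7-fold higher number from compound 1 to compound 4 (0.76 log units; beyond the scatter), so methyl now stands apart from two replacements rather than one. Methoxy, with no hydrogen-bond donor, ends at the same assay limit as methylamino; the steps from compound 2 and from compound 3 to compound 4 join two limits and cannot be read. Compound 1 alone holds a number: the limit of > 20000 nM in this assay, at which 3 of the 4 values shown sit.

From the compounds shown here alone, how far compound 2, compound 3 and compound 4 lie past the limit stays open. So does whether an unsubstituted amino group, chlorine or an ethyl chain on this carbon would give a measurable value.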